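The source may report more compounds than this note shows. Statements on the series, on what has been measured and on what is new or still open speak of the compounds shown alone.

Measured compounds in this series:
- compound 1 `O=C1OCC[C@@H]1NC(=S)SCCOc1ccc([N+](=O)[O-])cc1`: 32500 nM
- compound 2 `C=CCc1ccc(OCCSC(=S)N[C@H]2CCOC2=O)c(OC)c1`: > 64000 nM
- compound 3 `O=C(COc1ccc(C(=O)/C=C/c2ccccc2Br)cc1)N[C@H]1CCOC1=O`: 3260 nM

In a functional assay on PC-3 cells (Homo sapiens) for antiproliferative activity, read by MTT assay, with a stated time of 72 h (on this read-out lower numbers stand for stronger inhibition and higher numbers for weaker inhibition), compound 1 gives 32500 nM, the higher of the two numbers that are actual numbers. Compound 3 gives 3260 nM, a lower number, with a gap to compound 1 that lies beyond the scatter of repeated measurements. The value of compound 2 is a limit of the assay and not a number, as one of the three values sits at the limit of > 64000 nM in this assay, at which 1 of the 3 values shown sits.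

Compound 4 `O=C1OCC[C@@H]1NC(=S)SCCOc1ccc(Cl)cc1` is the next compound of interest. It differs from compound 1 in one place: chloro in place of nitro on an aromatic carbon. Within the data shown here, no pair of measured compounds in this set differs by this same change, so nothing measured here tells how the shared core responds to it. The expectation is therefore that compound 4 stays near compound 1, with a step of a 1.2-fold higher number from compound 1 to compound 4 (0.09 log units; within the scatter) that is expected to be small and not clearly beyond the scatter in either direction. Compound 4 is estimated at 40000 nM, expected to fall between 15000 nM and 100000 nM.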

Compound 4, half-maximal inhibitory concentration: > 64000 nM
Compound 4: no number, only a limit (the forecaster's own chance of this, stated with the estimate: 30%); middle value at least 1.6-fold (0.20 log units) from the limit.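

In this assay chloro in place of nitro on an aromatic carbon, para to a large group, gives an at least 1.9-fold higher number from compound 1 to compound 4 (0.29 log units; that floor lies within the scatter) and so shows no gain in inhibition from this change. From the compounds shown here alone, the value of compound 4 is a limit of the assay and not a number, so only a floor for this step can be read and its true size remains unknown. Among these compounds, this is the first change at this position that can be read, and it adds a second compound at the same limit: the limit of > 64000 nM in this assay, at which 2 of the 4 values shown sit.

With only nitro and chloro shown at this position, the role of the nitro group remains unsettled. Going by these compounds, how an amine or a carboxylic acid on the same aromatic carbon would read in this assay remains open.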